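Trimming the isothiocyanate linker under a macrophage tolerance test

A few compounds are considered here, and "the series" means these few. Any claim that something is new, unique, unknown or untested is made for them only; others in the source may bear on it.

Compound 1, `COc1ccc(S(=O)(=O)N(CC(N)=O)c2ccc(N(CC(N)=O)S(=O)(=O)c3ccc([S+]([O-])CCN=C=S)cc3)c3ccccc23)cc1`, was examined in an ADME assay on cells (Peritoneal macrophage, Mus musculus) for cytotoxicity, read by CCK-8 assay, with a stated time of 24 h; a lower number here means that less compound is tolerated, a higher number that more compound is tolerated. In this assay compound 1 gives only a limit, > 10000 nM. Compound 2, `COc1ccc(S(=O)(=O)N(CC(N)=O)c2ccc(N(CC(N)=O)S(=O)(=O)c3ccc(S(=O)(=O)CCOCCOCCOCCN=C=S)cc3)c3ccccc23)cc1`, likewise gives in this assay only a limit, > 10000 nM. Both measured values therefore sit at the same edge: the limit of > 10000 nM in this assay, at which 2 of the 2 values shown sit. On the numbers shown, compound 1 stands at that limit, and nothing separates it from compound 2. For the measured compounds named here, no step between measured compounds that differ in one place is available.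

Compound 3, `COc1ccc(S(=O)(=O)N(CC(N)=O)c2ccc(N(CC(N)=O)S(=O)(=O)c3ccc(N=C=S)cc3)c3ccccc23)cc1`, has not yet been measured in this assay. It differs from compound 1 by a group of 3 heavy atoms (1 carbon, 1 nitrogen, 1 sulfur; no ring) in place of a group of 7 heavy atoms (3 carbon, 1 nitrogen, 1 oxygen, 2 sulfur; no ring), on an aromatic carbon. With both known values resting at the limit, the step from compound 1 to compound 3 in this assay is expected to be small, none beyond the scatter, and most likely to end again at a limit rather than a number. For compound 3 the estimated value is 15000 nM, expected to fall between 5000 nM and 50000 nM. The expected step is a step that the limit leaves unreadable from compound 1 to compound 3.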

Compound 3, half-maximal cytotoxic concentration: > 10000 nM
Compound 3: only a limit was reported; the forecaster's own chance of this, stated with the estimate: 70%; the middle value lies beyond the limit too.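

In this assay compound 3 gives only a limit, > 10000 nM. For the compounds shown here, no step from compound 1 to compound 3 can be read, because the values share one edge: the limit of > 10000 nM in this assay, at which 3 of the 3 values shown sit. The compounds shown leave open at what concentration any of them becomes cytotoxic, and whether the linker matters for that.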